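The source may report more compounds than this note shows. Statements on the series, on what has been measured and on what is new or still open speak of the compounds shown alone.

Compound 1 `COc1cc(-c2nn(-c3cccc(NC(=O)Nc4ccc(Cl)c(Cl)c4)c3)cc2-c2ccncc2)ccc1Cl` gives 12900 nM in a functional assay on MDA-MB-231 cells (Homo sapiens) for inhibition, read by sulforhodamine B assay, with a stated time of 48 h; a higher number here means that more compound is tolerated, a lower number that less compound is tolerated. Compound 2 `O=C(Nc1cccc(-n2cc(-c3ccncc3)c(-c3ccc(Cl)c(O)c3)n2)c1)Nc1ccc(Cl)c(Cl)c1` reaches only a limit of the assay in this assay, recorded as > 32500 nM. The step of an at least 2.5-fold higher number from compound 1 to compound 2 (0.40 log units; beyond the scatter) rests on (the limit of > 32500 nM in this assay, at which 1 of the 2 values shown sits), so its true size is not known. Compound 3 `O=C(Nc1cccc(-n2cc(-c3ccncc3)c(-c3ccc(Cl)c(O)c3)n2)c1)Nc1ccc(Cl)c(C(F)(F)F)c1` differs from compound 2 by trifluoromethyl in place of chloro on an aromatic carbon. Among the measured compounds shown here, no measured step covers this kind of change, so no shift beyond the scatter can be foreseen, and compound 2 sits at the limit already. For compound 3 the expected step is a step that the limit leaves unreadable from compound 2 to compound 3. Compound 3 is therefore estimated at 40000 nM, within 15000 nM to 100000 nM, most likely again as a limit.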

Compound 3, concentration lethal to 50% of the cells: 11400 nM
Compound 3: middle estimate off by 3.5-fold (0.55 log units), on the high side; measured number outside the range, below it.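

In this assay, replacing 3,4-dichlorophenyl with 4-chloro-3-(trifluoromethyl)phenyl gives an at least 2.8-fold lower number from compound 2 to compound 3 (0.45 log units; beyond the scatter). This end of the molecule can therefore move the number too, whereas the earlier step concerned only the oxygen on another aromatic ring. The true size of the step stays unknown because the value of compound 2 is a limit: the limit of > 32500 nM in this assay, at which 1 of the 3 values shown sits.

As far as these compounds go, whether a nitrile or a methyl group at this place would act like trifluoromethyl remains open. So does whether the same change would shift the number with the methyl on the oxygen kept, as in compound 1.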